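The compounds below may be only part of what the source reports. "The series", "measured", "known", "first", "only" and "open" are said of these compounds alone.

Measured so far in a functional assay on the whole organism (strain albino) for inhibition, with Rattus norvegicus as the target, read by paw edema, with stated times of 30 min and 5 h, at a dose of 100 mg/kg by the oral route; a lower number here means less inhibition, a higher number more inhibition at the dose given (going by the name of the read-out):
compound 1 `Nc1ccc(C(=O)/C=C/c2ccc(Cl)cc2)cc1`, 54%
compound 2 `Nc1ccc(C(=O)/C=C/c2ccco2)cc1`, 30%
compound 3 `O=C(CBr)Nc1ccc(C(=O)/C=C/c2ccc(Cl)cc2)cc1`, 54%

Compound 3 stands level with compound 1 at the digits given, the two together the highest of the three; compound 2 gives a clearly lower number. For the measured compounds named here, the only step in this assay, no change at the digits printed from compound 1 to compound 3 (within the scatter), left the number unchanged within the scatter. Compound 4 `COc1ccc(/C=C/C(=O)c2ccc(NC(=O)CBr)cc2)cc1` differs from compound 3 by methoxy in place of chloro on an aromatic carbon. Going by the values given here, no measured step exchanges one substituent for another on that ring, so nothing bears directly on this change; the one step available, (bromomethyl)carbonyl in place of hydrogen, was flat. The step of a number 4 percentage points lower from compound 3 to compound 4 (within the scatter) is therefore expected to be small, with no direction beyond the scatter. Compound 4 is estimated at 50%, between 35% and 65%.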

Compound 4, a percentage reported as inhibition, in the whole organism at one dose (the size of the read-out at that dose, not a potency): 34%
For compound 4 the middle estimate is 16 percentage points above the measured one; measured number below the stated range.
By their numbers in this assay, from the lowest: compounds 2 and 4 (each within the scatter of the next); then compounds 1 and 3 (each within the scatter of the next).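

In this assay, methoxy in place of chloro on the aromatic carbon para to a large group gives a number 20 percentage points lower from compound 3 to compound 4 (beyond the scatter), whereas the (bromomethyl)carbonyl change on the nitrogen gave no change at the digits printed from compound 1 to compound 3 (within the scatter). This position is therefore not indifferent to its substituent, and of these two groups chloro gives the higher number. Nothing measured here accounts for the step.

As far as these compounds go, it remains open whether the step reflects the loss of chloro or the arrival of methoxy, which a fluoro, methyl or hydroxy group at this position could help separate. Also open, from the compounds shown here alone, is whether the same exchange on compound 1, with its free amine, gives a step of similar size.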